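A few compounds are considered here, and "the series" means these few. Any claim that something is new, unique, unknown or untested is made for them only; others in the source may bear on it.

In a functional assay on MV4-11 cells (Homo sapiens) for antiproliferative activity, read by CCK-8 assay, with a stated time of 72 h (a higher number here means a weaker inhibitor, a lower number a stronger inhibitor), compound 3 (`Cn1cc(-c2ccccc2F)c2cc(C(=O)NCc3ccc(C(=O)Nc4ccccc4N)cc3)[nH]c2c1=O`) gives 230 nM, within the scatter of compound 1 (`Cn1cc(-c2ccccc2Oc2ccccc2)c2cc(C(=O)NCCCCCCC(=O)NO)[nH]c2c1=O`) at 180 nM and well below compound 2 (`Cn1cc(-c2cccc(C(C)(C)O)c2)c2cc(C(=O)NCc3ccc(C(=O)Nc4ccccc4N)cc3)[nH]c2c1=O`) at 2200 nM. Compound 4 (`CC(C)Oc1ccccc1-c1cn(C)c(=O)c2[nH]c(C(=O)NCc3ccc(C(=O)Nc4ccccc4N)cc3)cc12`) carries isopropoxy in place of fluoro on an aromatic carbon, ortho to a large group: isopropoxy in place of fluoro on an aromatic carbon. Within the data shown here, only one measured step bears on this ring, a 9.6-fold lower number from compound 2 to compound 3 (0.98 log units; beyond the scatter), a modest change that involves a different substituent and so guides the size of the new step only loosely. No step beyond the scatter is expected: the estimated change in this assay is a 1.3-fold higher number from compound 3 to compound 4 (0.12 log units; within the scatter), towards a slightly higher number. Compound 4 is expected at 300 nM, with an estimated range of 110 nM to 800 nM.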

Compound 4, half-maximal inhibitory concentration: 130 nM
Beside the measured number, compound 4's estimate is 2.3-fold (0.36 log units) above it; low and high end bracket the measured number.
By their numbers in this assay, from the lowest: compounds 4, 1 and 3 (each within the scatter of the next); then compound 2.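

In this assay, a 1.8-fold lower number from compound 3 to compound 4 (0.25 log units; within the scatter) shows that this aromatic carbon, ortho to a large group, carries isopropoxy as well as fluoro. With a 17-fold lower number from compound 2 to compound 4 (1.23 log units; beyond the scatter), 2-isopropoxyphenyl, like 2-fluorophenyl, stands well apart from 3-(1-hydroxy-1-methylethyl)phenyl, so that gap does not rest on fluoro alone. No measured evidence accounts for either step.

Still open, from the compounds shown here alone, is whether an amine or a carboxylic acid on this carbon stays in the same range. Also open, going by these compounds, is whether 2-isopropoxyphenyl behaves the same way alongside the chain of compound 1.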